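This account rests on a few compounds, and the source may have more. Where it says the series, first, only, none or still open, it means among the compounds named here.

Working notes on the series, read out in a functional assay on HCT-116 cells (Homo sapiens) for inhibition, read by sulforhodamine B assay, with a stated time of 48 h, tested at 50 uM (on this read-out lower numbers stand for less inhibition of growth and higher numbers for more inhibition of growth at the one concentration tested), throughout. Compound 1 (`COc1ccc([C@@H]2C/C(=N/OCc3cn(-c4ccc(O)cc4)nn3)c3cc(CC=C(C)C)c(OC)cc3O2)cc1`) carries hydroxy and gives 65% here, compound 2 (`COc1ccc([C@@H]2C/C(=N/OCc3cn(-c4ccc(C#N)cc4)nn3)c3cc(CC=C(C)C)c(OC)cc3O2)cc1`) carries cyano and gives 50% here, and compound 3 (`COc1ccc([C@@H]2C/C(=N/OCc3cn(-c4ccc(C(N)=O)cc4)nn3)c3cc(CC=C(C)C)c(OC)cc3O2)cc1`) carries carbamoyl and gives 100% on the same read-out. Compound 3 is the highest of the three, with both gaps beyond the scatter.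

The next compound is compound 4 (`COc1ccc([C@@H]2C/C(=N/OCc3cn(-c4ccc(NC(=O)c5ccccc5)cc4)nn3)c3cc(CC=C(C)C)c(OC)cc3O2)cc1`). The change (benzamido in place of carbamoyl on an aromatic carbon) is benzamido in place of carbamoyl on an aromatic carbon, para to a large group. The steps at this same place are a number 35 percentage points higher from compound 1 to compound 3 (beyond the scatter) and a number 50 percentage points higher from compound 2 to compound 3 (beyond the scatter) (both large) and a number 15 percentage points lower from compound 1 to compound 2 (beyond the scatter) (modest), so swaps here have moved the read-out in both directions. Within the data shown here, no measured compound carries benzamido, which leaves the direction poorly supported. Compound 3 already gives 100% on this scale, so little rise is possible and a large fall is expected in this assay overall. The estimated change is a number 30 percentage points lower from compound 3 to compound 4 (beyond the scatter) with wide uncertainty. For compound 4 the expected value is 70% with an estimated range from 40% to 100% on this read-out.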

Compound 4, percent growth inhibition at one concentration: 8%
Compound 4: the middle estimate sits 62 percentage points above what was measured, outside the stated range (below it).
By their numbers in this assay, from the lowest: compound 4; then compound 2; then compound 1; then compound 3.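

Benzamido is the first group at this place to fall below all three others, giving a number 92 percentage points lower from compound 3 to compound 4 (beyond the scatter) and a number 42 percentage points lower from compound 2 to compound 4 (beyond the scatter) and a number 57 percentage points lower from compound 1 to compound 4 (beyond the scatter) on the same read-out. Carbamoyl and benzamido have the same counted hydrogen-bond donor and acceptor, so matching those counts does not by itself carry over the high number of compound 3. No measured evidence on the cause of this fall is at hand.

The compounds shown leave open whether the fall goes with the added six-membered aromatic ring or with the amide nitrogen now standing on the aromatic carbon. Acetamido and phenylcarbamoyl at this same place would separate these two readings, and a carboxylic acid would show how far the high number of compound 3 depends on the amide itself.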